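The source may report more compounds than this note shows. Statements on the series, on what has been measured and on what is new or still open speak of the compounds shown alone.

Compound 1, `CCOCCn1c(N2CCN(C)CC2)nc2ccccc21`: 10 nM
Compound 2, `CCCCCCn1c(N2CCN(C)CC2)nc2ccccc21`: 26 nM
Compound 3, `CN1CCN(c2nc3ccccc3n2-c2ccccc2)CC1`: 760 nM

The three measured compounds share one core and differ only in the group carried on an aromatic nitrogen. In a functional assay on ileum for inhibition of histamine H1 receptor (Cavia porcellus) (a higher number here means a weaker inhibitor, a lower number a stronger inhibitor), compound 1 gives the lowest number of the three: compound 2 lies at a 2.6-fold higher number from compound 1 to compound 2 (0.41 log units; beyond the scatter), and compound 3 at a 76-fold higher number from compound 1 to compound 3 (1.88 log units; beyond the scatter). The step of a 29-fold higher number from compound 2 to compound 3 (1.47 log units; beyond the scatter) tells the same story, the phenyl compound standing far behind both chain compounds.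

Compound 4, `CCCn1c(N2CCN(C)CC2)nc2ccccc21`, is reached from compound 1 by a single change: methyl in place of ethoxy on a saturated chain carbon, two bonds along the chain from an aromatic nitrogen. The nearest guide is the step of a 2.6-fold higher number from compound 1 to compound 2 (0.41 log units; beyond the scatter), in which the ethoxy likewise left the chain and a carbon group took its place; the outcome there was a modest loss. Within the data shown here, in compound 4 the chain becomes shorter rather than longer, and no measured pair covers a shortening, so that guide is only partial. A modest rise in this assay is the expectation, of about the size seen with compound 2, and no large shift of the kind seen with compound 3. Compound 4 is therefore expected to give 25 nM, within a range of 8 nM to 80 nM. This corresponds to an expected step of a 2.5-fold higher number from compound 1 to compound 4 (0.40 log units; beyond the scatter).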

Compound 4, half-maximal inhibitory concentration: 380 nM
The estimate for compound 4 lay 15-fold (1.18 log units) below the measured number; measured number above the stated range.
By their numbers in this assay, from the lowest: compound 1; then compound 2; then compounds 4 and 3 (each within the scatter of the next).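

Read in this assay, the change from ethoxy to methyl is far from the modest loss seen with hexyl: the step is a 38-fold higher number from compound 1 to compound 4 (1.58 log units; beyond the scatter), while the two all-carbon chains are themselves well apart, with a 15-fold higher number from compound 2 to compound 4 (1.16 log units; beyond the scatter), so what matters at this position is not only that the ethoxy leaves but also what chain remains. The propyl chain gives no clear advantage over a phenyl group on the aromatic nitrogen, since the step of a 2.0-fold lower number from compound 3 to compound 4 (0.30 log units; within the scatter) lies within the scatter, and compounds 3 and 4 cannot be separated here. No measurement offered here accounts for the sharp difference between the propyl and hexyl chains, or for the difference between propyl and 2-ethoxyethyl.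

The compounds shown leave open where between propyl and hexyl the number changes, which a butyl or pentyl chain would help to locate. They also leave open how the chain end of compound 1 compares with other end groups, such as a methoxy group, a hydroxyl group or an amine.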